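Removing a methoxy group from a benzimidazole-derived aniline

The source may hold more compounds than are shown below. What is called first, only, known or untested is meant among the compounds shown, and "the series" means these compounds.

The three measured compounds share one core, with different substituents on the aromatic amine and on the bicyclic part. Compound 1 `Clc1ccccc1NCc1nc2ccc(Br)cc2[nH]1`, compound 2 `COc1ccc(NCc2nc3ccccc3[nH]2)cc1` and compound 3 `Cc1ccc(NCc2nc3ccc(Br)cc3[nH]2)cc1` were each tested in a functional assay on the whole organism (strain albino) for inhibition, with Rattus norvegicus as the target, read by paw edema, with a stated time of 60 min, at a dose of 100 mg/kg by the oral route; a higher number here means more inhibition at the dose given (going by the name of the read-out), a lower number less inhibition. There compound 1 gives 20%, compound 2 gives 26.6% and compound 3 gives 20%. The number of compound 2 sits at the upper end of the three, yet it differs from compound 1 and from compound 3 by less than the usual scatter of repeated measurements, so none of these three can be told apart on the numbers alone.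

Compound 4 `c1ccc(NCc2nc3ccccc3[nH]2)cc1` has not been measured in this assay. It differs from compound 2 in one place: hydrogen in place of methoxy on an aromatic carbon. Going by the values given here, no pair of measured compounds shows this change, so its effect has to be read from the spread of the three numbers, which is flat within the scatter.

On that basis the step from compound 2 to compound 4 is expected to be small, a number 2.6 percentage points lower from compound 2 to compound 4 (within the scatter), in no clear direction and not beyond the scatter. For compound 4 the expected value is 24%, with a range from 10% to 38%.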

Compound 4, a percentage reported as inhibition, in the whole organism at one dose (the size of the read-out at that dose, not a potency): 26.6%
Estimate against measurement, compound 4: 2.6 percentage points below; the range from low to high includes it.
By their numbers in this assay, from the lowest: compounds 1, 3, 2 and 4 (each within the scatter of the next).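

Going by these compounds alone, the pair compound 2 and compound 4 gives the first direct reading of this change, since the two differ in one place only: hydrogen in place of methoxy on an aromatic carbon gives no change at the digits printed from compound 2 to compound 4 (within the scatter) in this assay, where the earlier compounds offered only a flat spread across several differences at once. At this position, para to a large group, the methoxy group can therefore be lost without a change that this read-out can detect at the single dose used. No measurement of any property bears on this result, and the data offer no explanation for it.

As far as these compounds go, whether another group at this place, such as an amine, a carboxylic acid or a longer chain, would shift the number remains open. Also open, from the compounds shown here alone, is whether the same exchange would read the same way on the core of compound 3, which carries bromine, or at another dose or time point.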